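This account rests on a few compounds, and the source may have more. Where it says the series, first, only, none or still open, it means among the compounds named here.

Measured so far, in a functional assay on 786-0 cells (Homo sapiens) for inhibition, read by sulforhodamine B assay, with a stated time of 48 h; on this read-out lower numbers stand for stronger inhibition of growth and higher numbers for weaker inhibition of growth:
- Compound 1 `COc1cc(-c2cc(/C=C/C(=O)c3ccc(N)cc3)[nH]n2)cc(OC)c1OC` gives 2040 nM in this assay.
- Compound 2 `COc1ccc(C(=O)/C=C/c2cc(-c3cc(OC)c(OC)c(OC)c3)n[nH]2)cc1OC` gives 1400 nM in this assay.
- Compound 3 `COc1ccc(C(=O)/C=C/c2cc(-c3cc(OC)c(OC)c(OC)c3)n[nH]2)cc1` gives 1950 nM in this assay.

On these numbers compound 3 stands second highest of the three, nearest to compound 1 and furthest from compound 2; both gaps, a 1.0-fold lower number from compound 1 to compound 3 (0.02 log units; within the scatter) and a 1.4-fold higher number from compound 2 to compound 3 (0.14 log units; within the scatter), lie within the scatter, so the three compounds cannot be told apart on this read-out.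

Compound 4 `COc1cc(-c2cc(/C=C/C(=O)c3ccc(F)c(F)c3)[nH]n2)cc(OC)c1OC` is the next step from compound 3: 3,4-difluorophenyl in place of 4-methoxyphenyl on a carbonyl carbon. All three measured steps concern the same aryl ring on the carbonyl carbon, and each of them, a 1.5-fold lower number from compound 1 to compound 2 (0.16 log units; within the scatter), a 1.0-fold lower number from compound 1 to compound 3 (0.02 log units; within the scatter) and a 1.4-fold higher number from compound 2 to compound 3 (0.14 log units; within the scatter), stayed within the scatter. Among the compounds with values here, no measured compound carries fluorine on that ring, so the change itself is untested. Going by the steps seen, the expected step of a 1.0-fold lower number from compound 3 to compound 4 (0.01 log units; within the scatter) is none beyond the scatter. Compound 4 is therefore estimated at 1900 nM in this assay, within a range from 800 nM to 4500 nM.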

Compound 4, concentration for 50% growth inhibition: 3350 nM
For compound 4 the middle estimate is 1.8-fold (0.25 log units) below the measured one, and the stated range covers the measured number.
By their numbers in this assay, from the lowest: compounds 2, 3, 1 and 4 (each within the scatter of the next, the first and the last beyond it).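

In this assay, within the data shown here, 3,4-difluorophenyl on the carbonyl carbon produces the first step at this position to pass the scatter: a 2.4-fold higher number from compound 2 to compound 4 (0.38 log units; beyond the scatter), a modest change measured against 3,4-dimethoxyphenyl. Against the other two groups it stays within the scatter, with a 1.7-fold higher number from compound 3 to compound 4 (0.24 log units; within the scatter) and a 1.6-fold higher number from compound 1 to compound 4 (0.22 log units; within the scatter), so among the pairs involving compound 4, only compound 2 and compound 4 can be told apart. Fluorine on this ring therefore brings no gain in growth inhibition over the groups already seen, and only the comparison with 3,4-dimethoxyphenyl shows a real loss.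

No measured information on these compounds explains this difference. Open still is how a single fluorine, a chlorine, a carboxylic acid or a morpholine on this ring would read out.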